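The compounds below may be only part of what the source reports. "The series", "measured", "known", "first", "only" and "open" are said of these compounds alone.

Of the compounds shown here, three built on the same core have been measured so far. In an ADME assay on HEK293 cells (Homo sapiens) for cytotoxicity, read by MTT assay, with a stated time of 48 h (a higher number here means a weaker inhibitor, a lower number a stronger inhibitor), compound 3 `Cc1ccc(S(=O)(=O)/N=C(/CCNC2=CC(=O)c3ccccc3C2=O)Nc2cc(F)c(F)c(F)c2)cc1` gives 82600 nM, the highest of the three numbers. Compound 1 `COc1ccc(N/C(CCNC2=CC(=O)c3ccccc3C2=O)=N\S(=O)(=O)c2ccc(C)cc2)cc1` gives 35100 nM in this assay, and compound 2 `Cc1ccc(S(=O)(=O)/N=C(/CCNC2=CC(=O)c3ccccc3C2=O)Nc2ccc(F)c(F)c2)cc1` gives 55200 nM. The steps between them are small: a 2.4-fold higher number from compound 1 to compound 3 (0.37 log units; beyond the scatter), while a 1.5-fold higher number from compound 2 to compound 3 (0.18 log units; within the scatter) and a 1.6-fold higher number from compound 1 to compound 2 (0.20 log units; within the scatter). Only the largest of these, from compound 1 to compound 3, reaches beyond the scatter, and it is modest.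

Compound 4 `Cc1ccc(S(=O)(=O)/N=C(/CCNC2=CC(=O)c3ccccc3C2=O)NCc2ccccc2)cc1` is the next compound. It differs from compound 3 in one place: benzyl in place of 3,4,5-trifluorophenyl on an amine nitrogen. For the measured compounds named here, none of the measured steps changes an aryl group on that nitrogen into a benzyl group, so they bear on this change only loosely; they show that exchanging one group on this nitrogen for another has shifted the number by modest amounts at most. Compound 4 lacks the fluorines that accompany the highest number, so a somewhat lower number is expected for it, though the step is expected to stay near the scatter, as a 1.8-fold lower number from compound 3 to compound 4 (0.26 log units; within the scatter). Compound 4 is therefore estimated at 45000 nM in this assay, within a range from 18000 nM to 110000 nM.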

Compound 4, half-maximal inhibitory concentration: 80200 nM
Estimate against measurement, compound 4: 1.8-fold (0.25 log units) below; low and high end bracket the measured number.
By their numbers in this assay, from the lowest: compounds 1, 2, 4 and 3 (each within the scatter of the next, the first and the last beyond it).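

In this assay, for the compounds shown here, benzyl, the first group on this amine nitrogen that is not a substituted phenyl, gives no step beyond the scatter against 3,4,5-trifluorophenyl (a 1.0-fold lower number from compound 3 to compound 4 (0.01 log units; within the scatter)) or against 3,4-difluorophenyl (a 1.5-fold higher number from compound 2 to compound 4 (0.16 log units; within the scatter)). Going by these compounds alone, only the step from 4-methoxyphenyl lies beyond the scatter (a 2.3-fold higher number from compound 1 to compound 4 (0.36 log units; beyond the scatter)), and it is modest, so fluorine on the ring is not required for a number at this level: compound 4 carries none. Nothing measured here explains why these groups sit so close together.

Open, as far as these compounds go, is whether any group on this nitrogen can move the number far, for instance a short alkyl chain, a chain ending in an amine or one ending in a carboxylic acid. Also open, from the compounds shown here alone, is how much the number depends on the shared core.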